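Furan-2-yl in Place of 4-Fluorophenyl: Expected Growth Inhibition

This account rests on a few compounds, and the source may have more. Where it says the series, first, only, none or still open, it means among the compounds named here.

Compound 1: `CC1=CC[C@H](C(C)(C)NC(=S)N/N=C/c2ccc(O)cc2)CC1` — > 100000 nM
Compound 2: `CC1=CC[C@H](C(C)(C)NC(=S)N/N=C/c2ccc(F)cc2)CC1` — > 100000 nM

In a functional assay on NCI-H460 cells (Homo sapiens) for inhibition, read by sulforhodamine B assay, with a stated time of 48 h (a lower number here means a stronger inhibitor of growth, a higher number a weaker inhibitor of growth), compound 1 gives > 100000 nM, which is a limit of the assay and not a number. Compound 2 gives > 100000 nM in this assay, also a limit. The step that the two limits leave unreadable from compound 1 to compound 2 is therefore unreadable, both values sitting at the limit of > 100000 nM in this assay, at which 2 of the 2 values shown sit. Compound 3 `CC1=CC[C@H](C(C)(C)NC(=S)N/N=C/c2ccco2)CC1` differs from compound 2 by furan-2-yl in place of 4-fluorophenyl on a carbon with a double bond to nitrogen. Going by the values given here, no measured step bears on this change, so compound 3 is expected to remain near the limit, giving 100000 nM (range 30000 nM to 300000 nM), an expected step of a number no higher from compound 2 to compound 3 (the limit leaves the size open).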

Compound 3, concentration for total growth inhibition: 10800 nM
Estimate against measurement, compound 3: 9.3-fold (0.97 log units) above, outside the stated range (below it).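

Compound 3 shows that this position can carry the series off the limit of the assay. In this assay, furan-2-yl in place of 4-fluorophenyl on a carbon with a double bond to nitrogen gives an at least 9.2-fold lower number from compound 2 to compound 3 (0.96 log units; beyond the scatter), and furan-2-yl in place of 4-hydroxyphenyl gives an at least 9.2-fold lower number from compound 1 to compound 3 (0.96 log units; beyond the scatter). Both sizes are minimum sizes, as the starting values are limits and not numbers: the limit of > 100000 nM in this assay, at which 2 of the 3 values shown sit.

The compounds shown leave open whether the ring oxygen or the five-membered ring goes with the lower number. Going by these compounds, how a thiophen-2-yl or pyridin-2-yl group would read at this place also remains open.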